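Swapping fluoro for amino in compound 3

This account rests on a few compounds, and the source may have more. Where it says the series, first, only, none or still open, it means among the compounds named here.

Three close relatives sharing one core have been tested in a functional assay on A2058 cells (Homo sapiens) for antiproliferative activity, read by luminescence and CellTiter-Glo, with a stated time of 96 h; a higher number here means a weaker inhibitor, a lower number a stronger inhibitor. Compound 1 `NC(=O)c1ccc(-c2ccc(F)c(C(=O)Nc3c[nH]nc3C(=O)Nc3ccc(F)cc3)c2F)cn1` gives 295 nM, and compound 2 `CN1CCC(CNC(=O)c2cccc(-c3ccc(F)c(C(=O)Nc4c[nH]nc4C(=O)Nc4ccc(F)cc4)c3F)c2)CC1`, which carries a different side group, gives 3340 nM. Compound 3 `O=C(Nc1ccc(F)cc1)c1n[nH]cc1NC(=O)c1c(F)ccc(-c2ccc(F)nc2)c1F` gives 6310 nM. Among the compounds with values here, that number lies within the scatter of the one for compound 2, and it sits well on the weaker side of the one for compound 1.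

Compound 4 `Nc1ccc(-c2ccc(F)c(C(=O)Nc3c[nH]nc3C(=O)Nc3ccc(F)cc3)c2F)cn1` differs from compound 3 in a single place: amino in place of fluoro on an aromatic carbon. In words, this is amino in place of fluoro on an aromatic carbon, taking a 6-fluoropyridin-3-yl group to a 6-aminopyridin-3-yl group.

Within the data shown here, only one measured step touches this place: a 21-fold higher number from compound 1 to compound 3 (1.33 log units; beyond the scatter), with fluoro in place of carbamoyl. So fluoro is the weaker of the two groups measured here, and a replacement for it has room to gain. Amino itself has not been measured, so a partial recovery towards compound 1 at 295 nM seems the fair expectation, not a full one. In this assay the expected change is a 7.0-fold lower number from compound 3 to compound 4 (0.85 log units; beyond the scatter), a clear move to a lower number. For compound 4 the estimated value is 900 nM, with an expected range from 200 nM to 4000 nM.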

Compound 4, half-maximal inhibitory concentration: 8540 nM
Compound 4: middle estimate off by 9.5-fold (0.98 log units), on the low side; measured number outside the range, above it.
By their numbers in this assay, from the lowest: compound 1; then compounds 2, 3 and 4 (each within the scatter of the next, the first and the last beyond it).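

Going from the 6-fluoropyridin-3-yl group to the 6-aminopyridin-3-yl group gives a 1.4-fold higher number from compound 3 to compound 4 (0.13 log units; within the scatter) in this assay, so this read-out does not separate fluoro from amino at this place, even though amino adds the hydrogen-bond donor and acceptor counted for it. The carbamoyl group of compound 1 now stands apart from two different replacements instead of one, with a 29-fold higher number from compound 1 to compound 4 (1.46 log units; beyond the scatter) alongside a 21-fold higher number from compound 1 to compound 3 (1.33 log units; beyond the scatter). Among compounds 1, 3 and 4, then, only carbamoyl goes with the lower number, and having a hydrogen-bond donor and acceptor on this ring carbon is not enough on its own to match it.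

Nothing at hand gives a reason why carbamoyl differs from the other two groups. Still open, as far as these compounds go, is which part of carbamoyl matters, and a methyl amide, an acetamido group or a carboxylic acid at the same place would help to show whether the carbonyl, the amide hydrogens or the whole group goes with the lower number.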